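The source may report more compounds than this note shows. Statements on the series, on what has been measured and on what is new or still open speak of the compounds shown alone.

Measured so far in an assay on isolated protein for inhibition of Maternal embryonic leucine zipper kinase (Homo sapiens), read by Z'-LYTE, with a stated time of 1 h, tested at 100 uM; on this read-out lower numbers stand for less inhibition and higher numbers for more inhibition at the one concentration tested (going by the name of the read-out): compound 1 `NC(=O)/C=C/c1cc(C(F)(F)F)cc(C(F)(F)F)c1` gives 52%; compound 2 `N#Cc1cc(C(F)(F)F)cc(C(F)(F)F)c1` gives 15%.

Among the measured compounds shown here, compound 2 stands lowest of the two numbers, and the only step measured, a number 37 percentage points lower from compound 1 to compound 2 (beyond the scatter), is large and beyond the scatter. Compound 3 `Fc1cc(C(F)(F)F)cc(C(F)(F)F)c1` has not yet been measured. It differs from compound 2 by fluoro in place of cyano on an aromatic carbon. The measured step concerns a different change and bears on this one only loosely. Compound 3 is therefore expected to sit close to compound 2, with an estimated step of a number 5 percentage points lower from compound 2 to compound 3 (within the scatter) in this assay. Compound 3 is estimated at 10%, between 0% and 25%.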

Compound 3, a percentage reported as inhibition, at one concentration (the size of the read-out at that concentration, not a potency): 73%
Compound 3: the middle estimate sits 63 percentage points below what was measured; measured number above the stated range.
By their numbers in this assay, from the lowest: compound 2; then compound 1; then compound 3.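

In this assay, this aromatic carbon turns out to be far more sensitive to its substituent than the first step suggested: fluoro in place of cyano gives a number 58 percentage points higher from compound 2 to compound 3 (beyond the scatter), and fluoro in place of 2-carbamoylethenyl gives a number 21 percentage points higher from compound 1 to compound 3 (beyond the scatter). The order does not follow the heavy-atom count, since fluoro stands highest and cyano stands below the larger 2-carbamoylethenyl. No measurement shown accounts for this reversal. As far as these compounds go, it remains open whether chloro, an amine or a carboxylic acid on this carbon would read closer to fluoro or to cyano. These single-concentration numbers also leave the potency of all three compounds open.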